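A few compounds are considered here, and "the series" means these few. Any claim that something is new, unique, unknown or untested is made for them only; others in the source may bear on it.

Measured in a functional assay on HL-60 cells (Homo sapiens) for inhibition, read by CCK-8 assay, with a stated time of 48 h; on this read-out lower numbers stand for stronger inhibition and higher numbers for weaker inhibition:
- compound 1 `Cc1cc(C)cc(NC(=O)NCCNS(=O)(=O)c2ccc(-c3ccccc3Oc3ccc([N+](=O)[O-])c([N+](=O)[O-])c3)s2)c1`: 9100 nM
- compound 2 `O=C(NCCNS(=O)(=O)c1ccc(-c2ccccc2O[C@H]2CC[C@H](O)CC2)s1)Nc1ccc([N+](=O)[O-])cc1`: 8900 nM
- compound 3 `O=C(NCCNS(=O)(=O)c1ccc(-c2ccccc2Oc2ccc([N+](=O)[O-])c([N+](=O)[O-])c2)s1)Nc1cc(Cl)cc(Cl)c1`: 2300 nM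

Compound 3 has the lowest number of the three, and its gaps to compound 1 and compound 2 both lie beyond the scatter. The values of compound 1 and compound 2 lie within the scatter of each other.

The next compound is compound 4 `O=C(NCCNS(=O)(=O)c1ccc(-c2ccccc2Oc2ccc([N+](=O)[O-])c([N+](=O)[O-])c2)s1)Nc1ccc([N+](=O)[O-])cc1`, which differs from compound 3 on an amide-type nitrogen: 4-nitrophenyl in place of 3,5-dichlorophenyl on an amide-type nitrogen. In short, 4-nitrophenyl takes the place of 3,5-dichlorophenyl.

For the measured compounds named here, only one measured step changes the group on this nitrogen with the rest held constant: a 4.0-fold lower number from compound 1 to compound 3 (0.60 log units; beyond the scatter), a modest step beyond the scatter. It involves 3,5-dimethylphenyl rather than 4-nitrophenyl, so it gives a scale for changes here but no direct read on the new group. Compound 2 does carry 4-nitrophenyl on this nitrogen and gives 8900 nM, but the rest of its structure differs from that of compound 4, so it offers only weak support for a move upward.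

A small rise in this assay is therefore expected, no larger than the measured step. The expected step is a 2.2-fold higher number from compound 3 to compound 4 (0.34 log units; beyond the scatter). For compound 4 the estimated value is 5000 nM, with an expected range of 1800 nM to 13000 nM.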

Compound 4, half-maximal inhibitory concentration: 340 nM
Compound 4: middle estimate off by 15-fold (1.17 log units), on the high side; the measured number lies below the stated range.
By their numbers in this assay, from the lowest: compound 4; then compound 3; then compounds 2 and 1 (each within the scatter of the next).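

In this assay, for the compounds shown here, the group on the amide-type nitrogen has more influence than the earlier compounds could show: 4-nitrophenyl gives a 6.8-fold lower number from compound 3 to compound 4 (0.83 log units; beyond the scatter) and a 27-fold lower number from compound 1 to compound 4 (1.43 log units; beyond the scatter). With the rest of the structure held constant, the three groups at this nitrogen now fall in a clear order, with 4-nitrophenyl giving the lowest number, then 3,5-dichlorophenyl, then 3,5-dimethylphenyl. The high number of compound 2 cannot be attributed to 4-nitrophenyl as such, since this group is present in both compounds of the step of a 26-fold lower number from compound 2 to compound 4 (1.42 log units; beyond the scatter), where 3,4-dinitrophenyl replaces 4-hydroxycyclohexyl on the oxygen on the aromatic ring.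

The data shown offer no evidence on why 4-nitrophenyl stands out at this nitrogen. As far as these compounds go, it remains open whether the nitro group itself is needed, which 4-aminophenyl or 4-cyanophenyl on the same nitrogen would test, and whether the order of groups at this nitrogen holds when 4-hydroxycyclohexyl sits on the oxygen.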